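The source may hold more compounds than are shown below. What is called first, only, known or untested is meant among the compounds shown, and "the series" means these compounds.

Of the compounds shown here, three sharing one core have been measured so far. Compound 1 (`N#Cc1c[nH]c2c(NS(=O)(=O)c3ccc(C(=O)O)cc3)cccc12`) gives > 100 ug/mL in a functional assay on P388 cells (Mus musculus) for antiproliferative activity (on this read-out higher numbers stand for weaker inhibition and lower numbers for stronger inhibition), and this value is a limit of the assay, not a number. Compound 2 (`N#Cc1c[nH]c2c(NS(=O)(=O)c3ccc(C(N)=O)cc3)cccc12`) gives 2.5 ug/mL in the same test. Compound 3 (`N#Cc1c[nH]c2c(NS(=O)(=O)c3ccc(N)cc3)cccc12`) gives 0.72 ug/mL and so holds the lowest number among the compounds with a measured number. Compound 4 (`CS(=O)(=O)Nc1ccc(S(=O)(=O)Nc2cccc3c(C#N)c[nH]c23)cc1`) changes compound 3 at its amino group: methylsulfonyl in place of hydrogen on a nitrogen on an aromatic ring (amino to methanesulfonamido). Among the measured compounds shown here, no measured step makes this exact change. The closest evidence comes from the two steps that exchange the amino group for another group. One is modest (a 3.5-fold lower number from compound 2 to compound 3 (0.54 log units; beyond the scatter)) and the other large (an at least 130-fold lower number from compound 1 to compound 3 (2.14 log units; beyond the scatter)). The step of an at least 40-fold lower number from compound 1 to compound 2 (1.60 log units; beyond the scatter) bears on it only indirectly. In both exchanges, the compound without the amino group has the higher number, so a modest move to a higher number is expected in this assay for this change. The estimated step is a 2.8-fold higher number from compound 3 to compound 4 (0.44 log units; beyond the scatter) and it may not clear the scatter. Compound 4 is expected at 2 ug/mL with an estimated range of 0.5 ug/mL to 10 ug/mL.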

Compound 4, half-maximal inhibitory concentration: 3.5 ug/mL
For compound 4 the middle estimate is 1.8-fold (0.24 log units) below the measured one; the measured number falls inside the stated range.
By their numbers in this assay, from the lowest: compound 3; then compounds 2 and 4 (each within the scatter of the next). At a limit, above all of these: compound 1.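

In this assay, among the compounds shown here, methylsulfonyl in place of hydrogen on the nitrogen gives a 4.9-fold higher number from compound 3 to compound 4 (0.69 log units; beyond the scatter), so this position responds to a change on the nitrogen itself, whereas the earlier steps exchanged the whole amino group. Methanesulfonamido and carbamoyl on this aromatic carbon cannot be ordered, with a 1.4-fold higher number from compound 2 to compound 4 (0.15 log units; within the scatter), so the amino compound 3 remains the only one with a number clearly apart from the others. The step of an at least 28-fold lower number from compound 1 to compound 4 (1.45 log units; beyond the scatter) is large, and its starting point is a limit of the assay and not a number: the limit of > 100 ug/mL in this assay, at which 1 of the 4 values shown sits.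

From the compounds shown here alone, whether an acetyl or a methyl group on the same nitrogen would behave like methylsulfonyl remains open. So does the outcome for a longer chain on the sulfonyl, such as ethylsulfonyl, or for a hydroxy group in place of the amino group.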